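Chloro-methoxyphenyl sulfonamide: expectation from three weak analogues

The compounds below may be only part of what the source reports. "The series", "measured", "known", "first", "only" and "open" are said of these compounds alone.

Compound 1 `O=S(=O)(Nc1ccc2oc(-c3ccccc3)nc2c1)c1cccc(F)c1` is reported only as a limit in an assay on cells for inhibition of HSP60/HSP10 (Homo sapiens), with a stated time of 60 min; a lower number here means a stronger inhibitor, a higher number a weaker inhibitor: > 100000 nM.
Compound 2 `O=S(=O)(Nc1ccc2oc(-c3ccccc3)nc2c1)c1cccc(O)c1` gives in this assay a value of 76000 nM.
Compound 3 `COc1ccc(S(=O)(=O)Nc2ccc3oc(-c4ccccc4)nc3c2)cc1` is likewise reported only as a limit in this assay: > 100000 nM.

Compound 3 therefore has no number of its own, only a limit, and it shares the limit of > 100000 nM in this assay, at which 2 of the 3 values shown sit, with compound 1. The step of an at least 1.3-fold higher number from compound 2 to compound 3 (0.11 log units; that floor lies within the scatter) is all that can be read toward it; the step that the two limits leave unreadable from compound 1 to compound 3 cannot be sized. Compound 4 `COc1ccc(Cl)cc1S(=O)(=O)Nc1ccc2oc(-c3ccccc3)nc2c1` carries the change (5-chloro-2-methoxyphenyl in place of 4-methoxyphenyl on a sulfonyl sulfur). With compound 3 at a limit and compound 2 only slightly below it, no step beyond the scatter can be foreseen in this assay; the step of an at least 1.1-fold lower number from compound 3 to compound 4 (0.04 log units; that floor lies within the scatter) is an estimate within the scatter. Compound 4 is expected to give 90000 nM, between 25000 nM and 300000 nM, quite possibly again as a limit.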

Compound 4, half-maximal inhibitory concentration: > 100000 nM
Compound 4 gave a limit, no number; the forecaster's own chance of this, stated with the estimate: 55%; at least 1.1-fold (0.04 log units) between middle value and limit.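

With the 5-chloro-2-methoxyphenyl group on the sulfonyl sulfur, compound 4 in this assay is reported only as a limit, > 100000 nM. Against compound 2, the only readable step is an at least 1.3-fold higher number from compound 2 to compound 4 (0.11 log units; that floor lies within the scatter), while the steps between two limits cannot be read. Only compound 2, with its 3-hydroxyphenyl group, has a number, and the others share one ceiling: the limit of > 100000 nM in this assay, at which 3 of the 4 values shown sit.

As far as these compounds go, how compound 1, compound 3 and compound 4 rank beyond that limit remains open. Also open, from the compounds shown here alone, is whether an aminophenyl or a carboxyphenyl group on the sulfonyl sulfur would give a measurable value.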